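The source may report more compounds than this note shows. Statements on the series, on what has been measured and on what is new or still open speak of the compounds shown alone.

In a functional assay on the whole organism (strain Wistar) for inhibition, with Rattus norvegicus as the target, read by paw edema, with stated times of 60 min and 1 h, at a dose of 100 mg/kg by the oral route (a lower number here means less inhibition, a higher number more inhibition at the dose given (going by the name of the read-out)), compound 1 `CNC(=O)CC1CCc2cc(OC)c(OC)cc21` gives 15.6% and compound 2 `CCCCCCNC(=O)CC1CCc2cc(OC)c(OC)cc21` gives 47.6%, the higher of the two numbers shown. Going by the values given here, the single measured step, a number 32 percentage points higher from compound 1 to compound 2 (beyond the scatter), came with pentyl in place of hydrogen on a saturated chain carbon bound to an amide-type nitrogen. Compound 3 `COc1cc2c(cc1OC)C(CC(=O)NC1CCCCC1)CC2` differs from compound 2 by cyclohexyl in place of hexyl on an amide-type nitrogen. Among the compounds with values here, no measured step swaps a chain for a ring of the same size, so that step bears on it only loosely, and in this assay no step beyond the scatter is expected. Compound 3 is estimated at 45%, between 25% and 62%, a change of a number 2.6 percentage points lower from compound 2 to compound 3 (within the scatter).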

Compound 3, a percentage reported as inhibition, in the whole organism at one dose (the size of the read-out at that dose, not a potency): 50%
Compound 3: the middle estimate sits 5 percentage points below what was measured; the range from low to high includes it.
By their numbers in this assay, from the lowest: compound 1; then compounds 2 and 3 (each within the scatter of the next).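

In this assay, cyclohexyl in place of hexyl on the amide-type nitrogen gave a number 2.4 percentage points higher from compound 2 to compound 3 (within the scatter) and so a ring of six carbons reads like the open chain of six carbons at this position. Cyclohexyl in place of methyl gave a number 34.4 percentage points higher from compound 1 to compound 3 (beyond the scatter) and so the large rise seen with hexyl does not depend on an open chain. Nothing shown accounts for this result. The compounds shown leave open how a phenyl ring, a cyclopropyl ring or a longer chain such as octyl would read on this nitrogen, and whether an amine or a carboxylic acid on the cyclohexyl ring would keep the level.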